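Dimethylamino in place of isobutylamino: cytotoxicity expectation

A few compounds are considered here, and "the series" means these few. Any claim that something is new, unique, unknown or untested is made for them only; others in the source may bear on it.

Compound 1 `Nc1nc(NC2CC2)c2ncn(/C=C3/CC3(CO)CO)c2n1`, compound 2 `CC(C)CNc1nc(N)nc2c1ncn2/C=C1/CC1(CO)CO` and compound 3 `CCCCCCSc1nc(N)nc2c1ncn2/C=C1/CC1(CO)CO` share one core and were tested in an ADME assay on HFF cells (Homo sapiens) for cytotoxicity, with a stated time of 8 days; a lower number here means that less compound is tolerated, a higher number that more compound is tolerated. For compound 1 the result is a limit of the assay, > 300000 nM. Compound 2 likewise reaches only a limit, > 300000 nM. Compound 3 too stops at a limit, > 300000 nM. Compound 2 therefore stands at the same limit as its two neighbours, and the steps a step that the two limits leave unreadable from compound 1 to compound 2, a step that the two limits leave unreadable from compound 1 to compound 3 and a step that the two limits leave unreadable from compound 2 to compound 3 cannot be read in size. Compound 4 `CN(C)c1nc(N)nc2c1ncn2/C=C1/CC1(CO)CO` differs from compound 2 by dimethylamino in place of isobutylamino on an aromatic carbon. Going by the values given here, with the limit of > 300000 nM in this assay, at which 3 of the 3 values shown sit, as the only evidence, no step beyond the scatter in either direction is expected, and compound 4 is expected again at a limit, estimated at 300000 nM, between 100000 nM and 1000000 nM. The step expected for compound 4 is a number no higher from compound 2 to compound 4 (the limit leaves the size open).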

Compound 4, half-maximal cytotoxic concentration: > 300000 nM
Compound 4 ended at the assay's limit; the forecaster's own chance of this, stated with the estimate: 85%; the middle value lies on the limit itself.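

Going by these compounds alone, compound 4, like compound 1, compound 2 and compound 3, stands at a limit, so no step among them can be read. Left open is where the true value of each compound lies in this assay, and whether the groups exchanged on the aromatic carbon make any difference there.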